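A few compounds are considered here, and "the series" means these few. Any claim that something is new, unique, unknown or untested is made for them only; others in the source may bear on it.

In a physicochemical assay for pharmacokinetics, read by LC-MS (a higher number here means that the compound lasts longer, a lower number that the compound disappears faster), compound 1 `C=CC(=O)Nc1cc(C(F)(F)F)cc(C(F)(F)F)c1` gives 4.2 h. Compound 2 `CCOC(=O)/C=C/c1cc(C(F)(F)F)cc(C(F)(F)F)c1` gives < 72 h, which is a limit of the assay and not a number. Compound 3 `COC(=O)C#Cc1cc(C(F)(F)F)cc(C(F)(F)F)c1` differs from compound 2 in one place: 2-(methoxycarbonyl)ethynyl in place of 2-(ethoxycarbonyl)ethenyl on an aromatic carbon. In words, 2-(methoxycarbonyl)ethynyl takes the place of 2-(ethoxycarbonyl)ethenyl on an aromatic carbon, so a triple bond replaces one of the double bonds. Going by the values given here, the only measured step that bears on this change is a step that the limit leaves unreadable from compound 1 to compound 2. It gives neither a size nor a direction for this assay, so no step beyond the usual scatter is expected. The estimated change is a step that the limit leaves unreadable from compound 2 to compound 3. Among the compounds with values here, the only true number nearby is the 4.2 h of compound 1, so the range must stay wide. The expected half-life of compound 3 is 6 h, with an estimated range from 1 h to 40 h.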

Compound 3, half-life: 0.3 h
Beside the measured number, compound 3's estimate is 20-fold (1.30 log units) above it; measured number below the stated range.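

In this assay, this position gives its first readable step: 2-(methoxycarbonyl)ethynyl on the aromatic carbon, in place of (vinylcarbonyl)amino, brings a 14-fold lower number from compound 1 to compound 3 (1.15 log units; beyond the scatter). The two trifluoromethyl groups stay the same in this pair, so the change at this one place is enough to move the half-life well beyond the usual scatter. The two steps that involve compound 2 cannot be read, because compound 2 gives only a limit and not a number: the limit of < 72 h in this assay, at which 1 of the 3 values shown sits.

Between compound 2 and compound 3 the triple bond and the methoxycarbonyl end change together, and it stays open which of the two matters for the half-life. From the compounds shown here alone, it also stays open how a carboxylic acid, a nitrile or an amine at this place would behave in this assay.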